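Cyclohexyl for phenyl on the amide carbonyl of compound 3

A few compounds are considered here, and "the series" means these few. Any claim that something is new, unique, unknown or untested is made for them only; others in the source may bear on it.

Working notes on the series. Compound 1 `CCOC(=O)N1CCC(NCCNC(=O)c2ccccc2C)CC1` carries the open-chain diamine. In a functional assay on CHO cells for agonist activity at muscarinic acetylcholine receptor M5 (Rattus norvegicus) (a higher number here means that more compound is needed for the effect, a lower number that less compound is needed), compound 1 gives > 30000 nM, which is a limit of the assay. Compound 2 `CCOC(=O)N1CCC(N2CCC[C@@H](NC(=O)c3cccc(F)c3)C2)CC1` and compound 3 `CCOC(=O)N1CCC(N2CCC[C@@H](NC(=O)c3ccccc3)C2)CC1` share a closed core. Compound 2 gives > 10000 nM in this assay, a limit. Compound 3 gives > 10000 nM in this assay, likewise a limit. Compound 3 thus stands at the limit of > 10000 nM in this assay, at which 2 of the 3 values shown sit, and the remaining measured value sits at the limit of > 30000 nM in this assay, at which 1 of the 3 values shown sits. Among the measured compounds shown here, the only step between measured neighbours, a step that the two limits leave unreadable from compound 2 to compound 3, cannot be read in size, so no measured step informs the next change.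

Compound 4 `CCOC(=O)N1CCC(N2CCC[C@@H](NC(=O)C3CCCCC3)C2)CC1` differs from compound 3 by cyclohexyl in place of phenyl on a carbonyl carbon. With every value in the set a limit and no readable step, there is no ground to expect a departure from the limit. The expected step that the limit leaves unreadable from compound 3 to compound 4 is therefore taken as none beyond the scatter. Compound 4 is estimated at 30000 nM in this assay, with a range from 5000 nM to 100000 nM, most likely reported again only as a limit.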

Compound 4, half-maximal effective concentration: > 10000 nM
Compound 4: a limit, no number; the forecaster's own chance of this, stated with the estimate: 85%; the middle value is on the limit's open side.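

Compound 4 gives > 10000 nM in this assay, which is a limit. The steps to compound 4 from compound 2 and from compound 3 cannot be read in size. The compounds shown leave open whether any group on the amide carbonyl of the shared core gives a numerical value in this assay.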